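Swapping trifluoromethyl for fluoro on a growth inhibitor

The compounds below may be only part of what the source reports. "The series", "measured", "known", "first", "only" and "open" are said of these compounds alone.

- compound 1 (`CC1(/C=C/c2ccccc2)C=CC(=O)O1`) with 97200 nM in a functional assay on UACC-62 cells (Homo sapiens) for inhibition, read by sulforhodamine B assay, with a stated time of 48 h; a higher number here means a weaker inhibitor of growth, a lower number a stronger inhibitor of growth
- compound 2 (`CC1(/C=C/c2ccc(C(F)(F)F)cc2)C=CC(=O)O1`) with 15500 nM in this assay

Of these two compounds, compound 2 has the lower number, so it is the stronger inhibitor of growth. Going by the values given here, the only measured step is a 6.3-fold lower number from compound 1 to compound 2 (0.80 log units; beyond the scatter), which arose with trifluoromethyl in place of hydrogen on an aromatic carbon. It is modest but lies beyond the scatter.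

The next compound, compound 3 (`CC1(/C=C/c2ccc(F)cc2)C=CC(=O)O1`), carries fluoro in place of trifluoromethyl on an aromatic carbon. Among the compounds with values here, no measured step involves fluoro, so the guide is indirect. Within the data shown here, in the counted sense, fluoro is a smaller group than trifluoromethyl, and hydrogen is the one group already measured at that place without trifluoromethyl. Part of the earlier gain may therefore be lost, though probably not all of it. An estimated 2.6-fold higher number from compound 2 to compound 3 (0.41 log units; beyond the scatter) is what this reasoning expects in this assay, a move towards a higher number. Compound 3 is estimated at 40000 nM (expected range 16000 nM to 100000 nM).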

Compound 3, concentration for total growth inhibition: 55300 nM
The estimate for compound 3 lay 1.4-fold (0.14 log units) below the measured number; the range from low to high includes it.
By their numbers in this assay, from the lowest: compound 2; then compounds 3 and 1 (each within the scatter of the next).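

In this assay, putting fluoro where trifluoromethyl stood gives a 3.6-fold higher number from compound 2 to compound 3 (0.55 log units; beyond the scatter) and so shows that the earlier gain at this position does not carry over to every fluorine-bearing group: a single fluorine in that place does not match trifluoromethyl. Set against the compound with hydrogen at the same aromatic carbon, fluoro gives a 1.8-fold lower number from compound 1 to compound 3 (0.24 log units; within the scatter) and cannot be told apart from hydrogen here, whereas trifluoromethyl is separated from both by steps beyond the scatter. Nothing measured here accounts for this difference between the groups.

The three compounds leave open how other groups at this place would behave, for example chloro, methoxy, a nitrile, an amine or a carboxylic acid, and only such groups could show whether trifluoromethyl is a special case or one end of a wider trend. They also leave open whether the same order of groups would hold on cells other than the single line used for these numbers, since every comparison so far rests on that one growth read-out.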